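A few compounds are considered here, and "the series" means these few. Any claim that something is new, unique, unknown or untested is made for them only; others in the source may bear on it.

Measured compounds:
Compound 1 `COc1cc(-c2nn(-c3cccc(NC(=O)Nc4ccc(Cl)c(Cl)c4)c3)cc2-c2ccncc2)ccc1Cl`: in a functional assay on OVCAR-4 cells (Homo sapiens) for inhibition, read by sulforhodamine B assay, with a stated time of 48 h (a higher number here means a weaker inhibitor of growth, a lower number a stronger inhibitor of growth), compound 1 gives > 50000 nM, which is a limit of the assay and not a number.
Compound 2 `O=C(Nc1cccc(-n2cc(-c3ccncc3)c(-c3ccc(Cl)c(O)c3)n2)c1)Nc1ccc(Cl)c(Cl)c1`: in this assay compound 2 gives > 32500 nM, which is also a limit of the assay.

Going by the values given here, compound 2 stands only at a limit in this assay, and the one other value shown, for compound 1, is a limit as well, so neither compound has a measured number. Among the compounds with values here, the single step between measured compounds is a step that the two limits leave unreadable from compound 1 to compound 2; the two limits, the limit of > 32500 nM in this assay, at which 1 of the 2 values shown sits, and (the limit of > 50000 nM in this assay, at which 1 of the 2 values shown sits), leave its size unreadable. Compound 3 `O=C(Nc1cccc(-n2cc(-c3ccncc3)c(-c3ccc(Cl)c(O)c3)n2)c1)Nc1ccc(Cl)c(C(F)(F)F)c1` differs from compound 2 by trifluoromethyl in place of chloro on an aromatic carbon. Within the data shown here, no measured step of known size bears on this change, and the values shown give no sign of a readable step in this assay in either direction. Compound 3 is therefore expected to sit at a limit too, and its estimated value in this assay is 40000 nM, in a range from 10000 nM to 100000 nM. The step that this estimate means is expected to be a step that the limit leaves unreadable from compound 2 to compound 3.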

Compound 3, concentration for total growth inhibition: > 32500 nM
Compound 3: a limit, no number (the forecaster's own chance of this, stated with the estimate: 75%); the middle value lies beyond the limit too.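

In this assay compound 3 gives > 32500 nM, which is a limit of the assay and not a number. Compound 2 also stands at a limit, so the step to compound 3, trifluoromethyl in place of chloro, cannot be read. The compounds shown leave open how these two groups would compare in a readable range.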